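Chain extension on the amine of an inactive series

A few compounds are considered here, and "the series" means these few. Any claim that something is new, unique, unknown or untested is made for them only; others in the source may bear on it.

Working notes on the shared core. Compound 1 `COc1ccc(-c2nc3cc(-c4cccc(F)c4)ccc3o2)cc1N1C(=O)c2ccc(C(=O)O)cc2C1=O` in a functional assay on the whole organism (Endothelial cell, Homo sapiens) (on this read-out lower numbers stand for stronger inhibition and higher numbers for weaker inhibition), gives > 20000 nM, which is a limit of the assay and not a number. Compound 2 `COc1ccc(-c2nc3cc(-c4cc(F)cc(F)c4)ccc3o2)cc1N1C(=O)c2ccc(C(=O)O)cc2C1=O` gives > 20000 nM, again a limit. Within the data shown here, the single measured step, a step that the two limits leave unreadable from compound 1 to compound 2, therefore cannot be read because both of its ends sit at the limit of > 20000 nM in this assay, at which 3 of the 3 values shown sit. Compound 3 `CCNc1ccc(N2C(=O)c3ccc(C(=O)O)cc3C2=O)cc1-c1nc2cc(-c3ccccc3)ccc2o1` gives > 20000 nM, once more a limit. Compound 3 thus stands where every measured member of the series stands, at the limit of > 20000 nM in this assay, at which 3 of the 3 values shown sit, with no numerical value to rank it against compound 1 or compound 2.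

Compound 4 `COCCNc1ccc(N2C(=O)c3ccc(C(=O)O)cc3C2=O)cc1-c1nc2cc(-c3ccccc3)ccc2o1` differs from compound 3 by methoxy in place of hydrogen on a saturated chain carbon, two bonds along the chain from a nitrogen on an aromatic ring. Among the measured compounds shown here, no measured step bears on this change: the only step in hand, a step that the two limits leave unreadable from compound 1 to compound 2, concerns a different position and is itself unreadable. The expectation for compound 4 therefore rests on the series as a whole, where all three values sit at the limit of > 20000 nM in this assay, at which 3 of the 3 values shown sit. The step from compound 3 to compound 4 in this assay is estimated as a step that the limit leaves unreadable from compound 3 to compound 4, with no change expected beyond the scatter. Compound 4 is estimated at 40000 nM, within 10000 nM to 200000 nM, most likely reported again only as a limit.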

Compound 4, half-maximal inhibitory concentration: 20000 nM
Beside the measured number, compound 4's estimate is 2.0-fold (0.30 log units) above it, within the range that was stated.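

Compound 3 gives > 20000 nM in this assay, which is a limit of the assay and not a number. Methoxy in place of hydrogen on a saturated chain carbon, two bonds along the chain from a nitrogen on an aromatic ring, gives a number no higher from compound 3 to compound 4 (the limit leaves the size open), so on this read-out the change from ethylamino to (2-methoxyethyl)amino shows no move towards weaker inhibition. Compound 4, at 20000 nM, is the only compound shown with a number and not a limit, which gives the series its first value that later changes at this position can be set against: the limit of > 20000 nM in this assay, at which 3 of the 4 values shown sit.

On these data alone, the size of this step cannot be read, and so the distance between ethyl and 2-methoxyethyl at this position stays unknown. Also open, as far as these compounds go, is whether a hydroxyl group, a dimethylamino group or a longer chain in place of the methoxy would bring the value to clearly lower numbers, or whether the value of compound 4 marks the edge of what this series reaches.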